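A Fluorinated Three-Membered Ring in Place of a Propyl Chain

A few compounds are considered here, and "the series" means these few. Any claim that something is new, unique, unknown or untested is made for them only; others in the source may bear on it.

Three compounds share one core and differ only in the group on the carbonyl carbon. Compound 1 `CC(=O)N1CC2CC(C1)N2` carries the simplest of these groups; in an assay on CHO cells for agonist activity at Neuronal acetylcholine receptor; alpha3/alpha6/beta2/beta3 (Homo sapiens), read by FLIPR and calcium flux (a higher number here means that more compound is needed for the effect, a lower number that less compound is needed), compound 1 gives 750 nM. Compound 2 `CCCC(=O)N1CC2CC(C1)N2` lengthens that chain, and in this assay compound 2 gives 300 nM, the lowest of the three numbers. Compound 3 `O=C(C1CCCC1)N1CC2CC(C1)N2` carries a ring on the carbonyl carbon, and in this assay compound 3 gives 1600 nM, the highest of the three.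

Going by the values given here, the only step that can be followed one change at a time runs a 2.5-fold lower number from compound 1 to compound 2 (0.40 log units; beyond the scatter), so adding carbon to the chain lowered the number by a modest amount. Compound 3 and compound 2 are not joined by such a step, but their two values show that the ring-bearing compound needs more.

Compound 4 `O=C([C@H]1C[C@@H]1F)N1CC2CC(C1)N2` differs from compound 2 by 2-fluorocyclopropyl in place of propyl on a carbonyl carbon. This change removes carbon from the chain and brings in a ring, and both comparisons available, compound 1 with 750 nM and compound 3 with 1600 nM, point toward a higher number than compound 2. A fluorine-bearing three-membered ring is unlike either, so the expectation is held loosely. Compound 4 is expected to give about 650 nM, within a range from 200 nM to 2000 nM, which would mean a step of a 2.2-fold higher number from compound 2 to compound 4 (0.34 log units; beyond the scatter).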

Compound 4, half-maximal effective concentration: 620 nM
Compound 4: the middle estimate sits 1.0-fold (0.02 log units) above what was measured; the range from low to high includes it.
By their numbers in this assay, from the lowest: compound 2; then compounds 4 and 1 (each within the scatter of the next); then compound 3.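

The step of a 2.1-fold higher number from compound 2 to compound 4 (0.32 log units; beyond the scatter) shows that this place, on a carbonyl carbon bound to the amide-type nitrogen of the shared core, also responds when a chain gives way to a small fluorinated ring, and that the modest gain seen with propyl does not carry over to 2-fluorocyclopropyl. Set against the methyl group of compound 1, the step of a 1.2-fold lower number from compound 1 to compound 4 (0.08 log units; within the scatter) means that this ring and that much smaller group cannot be told apart here, even though the ring brings in a fluorine and two defined stereocentres. No measurement at hand explains why either step has the size it does.

Still open, from the compounds shown here alone, is how much of the step from propyl belongs to the three-membered ring and how much to the fluorine, a question that a plain cyclopropyl group at this place would help to settle. Also open, going by these compounds, is what the other stereoisomers of 2-fluorocyclopropyl would give, and whether a longer chain such as pentyl would extend the gain seen with propyl.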